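The source may report more compounds than this note shows. Statements on the series, on what has been measured and on what is new or still open speak of the compounds shown alone.

Compound 1 `C[C@H](NC(=O)CN(c1nc(Cl)nc2[nH]cnc12)C1CC1)C(=O)O` — 48.1%
Compound 2 `C[C@H](NC(=O)CN(c1nc(Cl)nc2[nH]cnc12)C1CC1)C(=O)OCc1ccccc1` — 41.2%
Compound 3 `NC(=O)C[C@H](NC(=O)CN(c1nc(Cl)nc2[nH]cnc12)C1CC1)C(=O)OCc1ccccc1` — 24.4%

In a functional assay on the whole organism (Tail, strain ICR) with Mus musculus as the target, in the tail flick test, with a stated time of 30 min, at a dose of 25 umol/kg by the oral route (a higher number here means a stronger effect of the compound at the dose given, a lower number a weaker effect), compound 1 gives the highest of the three numbers. Its nearest neighbour is compound 2, the step of a number 6.9 percentage points lower from compound 1 to compound 2 (within the scatter) being a change of a benzyl in place of hydrogen on an oxygen next to a carbonyl group, so the two values cannot be ordered. For the measured compounds named here, the only step beyond the scatter is a number 16.8 percentage points lower from compound 2 to compound 3 (beyond the scatter), where a carbamoyl replaces hydrogen on the side chain, and compound 3 therefore stands furthest from compound 1.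

Compound 4 `O=C(CN(c1nc(Cl)nc2[nH]cnc12)C1CC1)N[C@@H](CO)C(=O)O` has not yet been measured. It differs from compound 1 by hydroxy in place of hydrogen on a saturated chain carbon, two bonds along the chain from an amide-type nitrogen and a carbonyl carbon. Going by the values given here, the change sits at the same place as the change from compound 2 to compound 3, though the entering group is different and the ester of those two compounds is absent here; the step of a number 16.8 percentage points lower from compound 2 to compound 3 (beyond the scatter) is the only measured guide and points downward. A modest fall is therefore expected, estimated as a number 10.1 percentage points lower from compound 1 to compound 4 (beyond the scatter). Compound 4 is accordingly expected to give about 38% in this assay, within a range from 22% to 54%.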

Compound 4, a percentage reported as activity, at one dose (the size of the read-out at that dose, not a potency): 38.7%
Beside the measured number, compound 4's estimate is 0.7 percentage points below it, within the range that was stated.
By their numbers in this assay, from the lowest: compound 3; then compounds 4, 2 and 1 (each within the scatter of the next).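

In this assay the change from methyl to hydroxymethyl, on a saturated chain carbon two bonds along the chain from an amide-type nitrogen and a carbonyl carbon, gives a number 9.4 percentage points lower from compound 1 to compound 4 (within the scatter) and so does not separate the two compounds. The earlier compounds shown here showed this carbon only through a carbamoyl on the benzyl ester, with a number 16.8 percentage points lower from compound 2 to compound 3 (beyond the scatter) as a step beyond the scatter; the hydroxy on the free acid now shows that a substituent here need not bring a step of that kind. These two steps differ in both the entering group and the ester, so the data cannot say which of the two accounts for the contrast, and nothing measured here offers an explanation for either step.

From the compounds shown here alone, what remains open is whether hydroxy on the benzyl ester of compound 2 or carbamoyl on the free acid of compound 1 would match the step seen with the other pair. Also open, going by these compounds, is how an amine, a methoxy group or a longer chain on this same carbon would read in this assay at the dose given.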